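Swapping an Ester for a Ketone on a Growth Inhibitor

The compounds below may be only part of what the source reports. "The series", "measured", "known", "first", "only" and "open" are said of these compounds alone.

Compound 1 `C=C(C)[C@@H]1CC=C(Cn2cc(COc3ccc(C4NC(=O)NC(C)=C4C(=O)OCC)cc3)nn2)CC1` gives > 100000 nM in a functional assay on NCI/ADR-RES cells (Homo sapiens) for inhibition, read by sulforhodamine B assay, with a stated time of 48 h (on this read-out lower numbers stand for stronger inhibition of growth and higher numbers for weaker inhibition of growth), which is a limit of the assay and not a number.
Compound 2 `C=C(C)[C@@H]1CC=C(Cn2cc(COc3ccc(C4NC(=O)NC(C)=C4C(=O)OCC)cc3OC)nn2)CC1` gives > 100000 nM in this assay, again a limit of the assay.
Compound 3 `C=C(C)[C@@H]1CC=C(Cn2cc(COc3cc(C4NC(=O)NC(C)=C4C(C)=O)ccc3OC)nn2)CC1` gives 84900 nM in this assay.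

Compound 2 thus stands at the limit of > 100000 nM in this assay, at which 2 of the 3 values shown sit, so its own value is not a number. Within the data shown here, the only measured step that reaches compound 2, a step that the two limits leave unreadable from compound 1 to compound 2, cannot be read either, because both ends are limits.

Compound 4 `C=C(C)[C@@H]1CC=C(Cn2cc(COc3ccc(C4NC(=O)NC(C)=C4C(C)=O)cc3OC)nn2)CC1` differs from compound 2 by one change: methyl in place of ethoxy on a carbonyl carbon. Among the measured compounds shown here, no measured step shows this change directly. For the measured compounds named here, compound 3, which also carries the acetyl group, gives a number for this assay that lies close to the limit, and nothing among the measured compounds points to a step beyond the scatter.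

Compound 4 is therefore expected near the limit, with an estimated step of a number no higher from compound 2 to compound 4 (the limit leaves the size open) from compound 2. The estimate for compound 4 is 100000 nM, with a range from 40000 nM to 300000 nM.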

Compound 4, concentration for total growth inhibition: 80200 nM
Compound 4: middle estimate off by 1.2-fold (0.10 log units), on the high side; measured number inside the range.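

In this assay, compound 2 gives > 100000 nM, which is a limit of the assay and not a number. Once methyl replaces ethoxy on the carbonyl carbon, compound 4 gives a true number, 80200 nM, so the change can be given a direction, though only a weak one: the measured change is an at least 1.2-fold lower number from compound 2 to compound 4 (0.09 log units; that floor lies within the scatter). Its real size stays unknown because one end of the step is a limit: the limit of > 100000 nM in this assay, at which 2 of the 4 values shown sit.

The compounds shown leave open whether any other group on this carbonyl carbon, such as an amine or a hydroxyl that would make a carboxylic acid, could bring the number clearly below this range. They also leave open whether a longer chain in place of methyl would keep the number readable.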